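The compounds below may be only part of what the source reports. "The series", "measured", "known", "first", "only" and "open" are said of these compounds alone.

Three compounds of a shared core carry a chloromethyl-substituted benzyl group; compound 1 `ClCc1ccccc1Cn1cnc2c(Cl)nc(Cl)nc21`, compound 2 `ClCc1cccc(Cn2cnc3c(Cl)ncnc32)c1` and compound 3 `ClCc1cccc(Cn2cnc3nc(Cl)nc(Cl)c32)c1` differ in how many chloro groups the core bears and where the benzyl arm sits. In a functional assay on Hs-578T cells (Homo sapiens) for cytotoxicity, read by sulforhodamine B assay, with a stated time of 48 h (a higher number here means that more compound is tolerated, a lower number that less compound is tolerated), compound 1 gives > 100000 nM, which is a limit of the assay and not a number. For compound 3 the entry in this assay reads "not determined" (no result reported), so no result was reported. Compound 2 gives 81300 nM in this assay. For the measured compounds named here, it is the only compound of the set with a definite number, so it stands as the sole reference point; one further value is only a limit of > 100000 nM in this assay, at which 1 of the 3 values shown sits, and one entry is empty.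

Compound 4 `Nc1nc(Cl)c2ncn(Cc3cccc(CCl)c3)c2n1` is built from compound 2 by the change (amino in place of hydrogen on an aromatic carbon), that is, amino in place of hydrogen on an aromatic carbon. Going by the values given here, no step between measured compounds shows what such a change does here. The expected step from compound 2 to compound 4 in this assay is a 1.1-fold higher number from compound 2 to compound 4 (0.04 log units; within the scatter), a small shift toward more compound being tolerated that may not exceed the scatter. Compound 4 is therefore estimated at 90000 nM in this assay, with a range from 30000 nM to 200000 nM.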

Compound 4, concentration lethal to 50% of the cells: > 100000 nM
Compound 4 gave a limit, no number (the forecaster's own chance of this, stated with the estimate: 40%); at least 1.1-fold (0.04 log units) between middle value and limit.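

For the compounds shown here, this is the first step in the set that shows what a change at this position does: with amino in place of hydrogen on an aromatic carbon, between two ring nitrogen atoms, this assay gives an at least 1.2-fold higher number from compound 2 to compound 4 (0.08 log units; that floor lies within the scatter). Compound 4 gives a limit of the assay and not a number, and it is the second compound to do so: the limit of > 100000 nM in this assay, at which 2 of the 4 values shown sit. The change therefore brings no lower number here, but the printed floor of the step lies within the scatter, so it does not establish a real rise, and its true size cannot be read.

The compounds shown leave open whether a hydroxyl group or a longer chain such as aminoethyl at this same place would give a similar result. They also leave open whether amino would act the same way on a core with a different chloro pattern.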